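The compounds below may be only part of what the source reports. "The series", "measured", "known", "first", "only" and "open" are said of these compounds alone.

Measured compounds:
- compound 1 `C#Cc1cccc(NC(=O)CCc2cccc3c2B(O)OC3)c1`: > 100000 nM
- compound 2 `C#Cc1ccccc1NC(=O)CCc1cccc2c1B(O)OC2`: 18000 nM
- compound 3 `O=C(CCc1cccc2c1B(O)OC2)Nc1ccc(-c2ccccc2)cc1`: 32000 nM

In an ADME assay on WI-38 cells (Homo sapiens) for cytotoxicity, read by MTT assay, with a stated time of 72 h (on this read-out lower numbers stand for stronger inhibition and higher numbers for weaker inhibition), compound 1 gives only a limit, > 100000 nM; no number is known for it. This is the limit of > 100000 nM in this assay, at which 1 of the 3 values shown sits. Compound 2 gives 18000 nM in this assay. Compound 3 gives 32000 nM in this assay. Compound 1 therefore stands at the weak end of the three, with compound 2 and compound 3 each returning a number rather than a limit.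

The next compound is compound 4 `O=C(CCc1cccc2c1B(O)OC2)Nc1cccc(-c2cccc(C(F)(F)F)c2)c1`, which is not yet measured in this assay. It differs from compound 1 in one place: 3-(trifluoromethyl)phenyl in place of ethynyl on an aromatic carbon.

Among the measured compounds shown here, no step between two measured compounds in this set differs in only one place, so the size of this step cannot be read from a measured pair. The expectation for this assay is a move toward lower numbers from compound 1, of a size beyond the usual scatter, since compound 3 with its value of 32000 nM shows that a compound of this series can return a number in this assay.

Compound 4 is estimated at 40000 nM, with a range from 15000 nM to 120000 nM, a step from compound 1 of an at least 2.5-fold lower number from compound 1 to compound 4 (0.39 log units; beyond the scatter).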

Compound 4, half-maximal inhibitory concentration: 23000 nM
The estimate for compound 4 lay 1.7-fold (0.24 log units) above the measured number; the measured number falls inside the stated range.
By their numbers in this assay, from the lowest: compounds 2, 4 and 3 (each within the scatter of the next). At a limit, above all of these: compound 1.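

In this assay, replacing ethynyl on this aromatic carbon with 3-(trifluoromethyl)phenyl gives an at least 4.3-fold lower number from compound 1 to compound 4 (0.63 log units; beyond the scatter). Among the compounds shown here, this is the first single-place change that can be read, and it shows that the read-out at this position responds to the change, moving from a limit for compound 1 to a number for compound 4. The step gives only a lower bound on the size of the change, because the value for compound 1 is a limit: the limit of > 100000 nM in this assay, at which 1 of the 4 values shown sits.

Open, as far as these compounds go, is how a plain phenyl, an amine or a carboxylic acid on the same aromatic carbon would compare, and therefore how much of the step belongs to the added aromatic ring and how much to the trifluoromethyl group. Also open, from the compounds shown here alone, is the full size of the step and whether the same change would give a similar move on a compound with a different attachment point on the aromatic ring bearing the amide.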